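This account rests on a few compounds, and the source may have more. Where it says the series, first, only, none or still open, it means among the compounds named here.

Compound 1 `O=C(/C(=C\c1ccc(F)cc1F)Sc1ccc(Br)cc1)c1ccc(Br)cc1` is the starting point. In a functional assay on DU-145 cells (Homo sapiens) for inhibition, read by trypan blue exclusion, with a stated time of 96 h (on this read-out higher numbers stand for weaker inhibition of growth and lower numbers for stronger inhibition of growth), compound 1 gives 1000 nM. Compound 3 `O=C(/C(=C\c1ccc(F)cc1F)Sc1ccc(Br)cc1)c1ccc(Cl)cc1` carries chloro in place of bromo on an aromatic carbon and gives 1000 nM, so no change at the digits printed from compound 1 to compound 3 (within the scatter) and compound 1 sits level with compound 3. Compound 2 `Cc1ccc(S/C(=C/c2ccc(F)cc2F)C(=O)c2ccc(Br)cc2)cc1` has methyl in place of bromo on an aromatic carbon. For compound 2 the read-out is only a limit, > 100000 nM, the limit described as the limit of > 100000 nM in this assay, at which 1 of the 3 values shown sits. That step is an at least 100-fold higher number from compound 1 to compound 2 (2.00 log units; beyond the scatter).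

The unmeasured compound 4 `Nc1c(Br)cc(Br)cc1/C=C(/Sc1ccc(Br)cc1)C(=O)c1ccc(Br)cc1` differs from compound 1 as follows: 2-amino-3,5-dibromophenyl in place of 2,4-difluorophenyl on a double-bonded chain carbon bound to a double-bonded chain carbon. Neither measured step alters this part of the molecule, since both change the ring on sulfur, so they bear on the new change only loosely: they show that one ring substitution may leave the number unchanged while another may lift it enormously. Among the compounds with values here, with no direct precedent, a modest rise is expected, a 2.5-fold higher number from compound 1 to compound 4 (0.40 log units; beyond the scatter), and compound 4 is estimated at 2500 nM, between 300 nM and 25000 nM.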

Compound 4, concentration for 50% growth inhibition: > 100000 nM
Compound 4 ended at the assay's limit (the forecaster's own chance of this, stated with the estimate: 15%); middle value at least 40-fold (1.60 log units) away from the limit.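

Replacing the 2,4-difluorophenyl with 2-amino-3,5-dibromophenyl on a double-bonded chain carbon bound to a double-bonded chain carbon gives an at least 100-fold higher number from compound 1 to compound 4 (2.00 log units; beyond the scatter) in this assay. Within the data shown here, this part of the molecule, untouched by the earlier steps, therefore does not accept every substituted phenyl ring without a large loss of growth inhibition. Compound 4 gives a limit rather than a number, so the full size of the loss stays unknown, and compound 2 shows that a change elsewhere in the molecule can end at the same limit: the limit of > 100000 nM in this assay, at which 2 of the 4 values shown sit.

The swap brings in the amino group and the two bromines while removing both fluorines, so the compounds shown cannot tell which of these changes matters. An unsubstituted phenyl ring, or one bearing a single methoxy group, would begin to separate them.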